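The source may report more compounds than this note shows. Statements on the series, on what has been measured and on what is new or still open speak of the compounds shown alone.

Of the compounds shown here, three built on one shared core have so far been tested in a functional assay on RPMI-8226 cells (Homo sapiens) for antiproliferative activity, read by radiometric assay, with a stated time of 72 h; a higher number here means a weaker inhibitor, a lower number a stronger inhibitor. Compound 1 `Cc1ccccc1Nc1ncnc2cc(NC(=O)CCCCCCC(=O)NO)sc12` gives 1750 nM there. Compound 2 `Cc1cc(F)ccc1Nc1ncnc2cc(NC(=O)CCCCCCC(=O)NO)sc12`, which carries a fluoro in place of hydrogen on an aromatic carbon, gives 1950 nM, and the step of a 1.1-fold higher number from compound 1 to compound 2 (0.05 log units; within the scatter) stays within the scatter. Compound 3 `O=C(CCCCCCC(=O)Nc1cc2ncnc(Nc3ccc(Cl)cc3F)c2s1)NO`, carrying 4-chloro-2-fluorophenyl in place of 2-methylphenyl on a nitrogen on an aromatic ring, gives 1900 nM. Neither a 1.1-fold higher number from compound 1 to compound 3 (0.04 log units; within the scatter) nor a 1.0-fold lower number from compound 2 to compound 3 (0.01 log units; within the scatter) rises above the scatter, so compound 3 sits in the middle of three numbers that cannot be told apart, nearest to compound 2 and furthest from compound 1.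

Compound 4 `N#Cc1cccc(Nc2ncnc3cc(NC(=O)CCCCCCC(=O)NO)sc23)c1` has not yet been measured in this assay. Relative to compound 3 its change is 3-cyanophenyl in place of 4-chloro-2-fluorophenyl on a nitrogen on an aromatic ring. The two earlier exchanges of the aryl group on that nitrogen, a 1.1-fold higher number from compound 1 to compound 3 (0.04 log units; within the scatter) and a 1.0-fold lower number from compound 2 to compound 3 (0.01 log units; within the scatter), both stayed within the scatter, as did a 1.1-fold higher number from compound 1 to compound 2 (0.05 log units; within the scatter); on that record compound 4 is expected to show no step beyond the scatter, that is no change at the digits printed from compound 3 to compound 4 (within the scatter). Within the data shown here, none of the measured compounds carries a nitrile, so the range is kept generous. In this assay compound 4 is therefore estimated at 1900 nM, with a range from 900 nM to 4000 nM.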

Compound 4, half-maximal inhibitory concentration: 1580 nM
Compound 4: the middle estimate sits 1.2-fold (0.08 log units) above what was measured, and the stated range covers the measured number.
By their numbers in this assay, from the lowest: compounds 4, 1, 3 and 2 (each within the scatter of the next).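

In this assay, among these compounds, the 3-cyanophenyl group brings a nitrile, with its triple bond and hydrogen-bond acceptor, to the nitrogen on the aromatic ring, and neither feature is found in the earlier compounds. Even so, the readings are a 1.2-fold lower number from compound 3 to compound 4 (0.08 log units; within the scatter) and a 1.2-fold lower number from compound 2 to compound 4 (0.09 log units; within the scatter) and a 1.1-fold lower number from compound 1 to compound 4 (0.04 log units; within the scatter) and each stays within the scatter, so the record at this position now extends to an aryl group without the fluorine and chlorine of compound 3 or the methyl group of compound 1, and no compound shown goes against the flat pattern among these four aryl groups. No evidence is available to explain this flat pattern.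

The compounds shown leave open whether an amine or a carboxylic acid on the aryl group, or a morpholine ring in place of that group, would also stay within the scatter. They also leave open whether a shorter or longer chain on the shared core would change the number in this assay more than any exchange on this nitrogen has.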